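Sulfonyl group exchange: compound 2 to compound 3

A few compounds are considered here, and "the series" means these few. Any claim that something is new, unique, unknown or untested is made for them only; others in the source may bear on it.

Among the measured compounds shown here, in a functional assay on DU-145 cells (Homo sapiens) for inhibition, read by trypan blue exclusion, with a stated time of 96 h (a higher number here means a weaker inhibitor of growth, a lower number a stronger inhibitor of growth), only two compounds have numbers so far. Compound 1 (`CCOc1ccc(/C=C(/SCc2ccc(C)cc2)C(=O)c2ccc(Cl)cc2)cc1OC`) gives 25000 nM and compound 2 (`CCOc1ccc(/C=C(\C(=O)c2ccc(Cl)cc2)S(=O)(=O)Cc2ccccc2Cl)cc1OC`) gives 10000 nM as the lower of the two numbers. Compound 3 (`CCOc1ccc(/C=C(\C(=O)c2ccc(Cl)cc2)S(=O)(=O)c2ccc(C)cc2)cc1OC`) is still unmeasured. It carries 4-methylphenyl in place of 2-chlorobenzyl on a sulfonyl sulfur.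

For the measured compounds named here, only one measured step bears on this change. That step (a 2.5-fold lower number from compound 1 to compound 2 (0.40 log units; beyond the scatter)) is modest and exchanges (4-methylbenzyl)sulfanyl for (2-chlorobenzyl)sulfonyl, so the sulfur group and its substituent change together. Going by the values given here, no measured pair varies the group on the sulfonyl sulfur alone, and the data therefore give no firm direction for the new exchange. The working expectation in this assay is no step beyond the scatter, with a range wide enough to allow a step of similar size in either direction. The expected change (a 1.2-fold higher number from compound 2 to compound 3 (0.08 log units; within the scatter)) leans only slightly towards a higher number. The estimate for compound 3 is 12000 nM with an expected range of 4000 nM to 35000 nM in this series.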

Compound 3, concentration for 50% growth inhibition: 1000 nM
For compound 3 the middle estimate is 12-fold (1.08 log units) above the measured one; the measured number lies below the stated range.
By their numbers in this assay, from the lowest: compound 3; then compound 2; then compound 1.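

In this assay the group on the sulfonyl sulfur matters on its own: with the rest of the structure held fixed, 4-methylphenyl in place of 2-chlorobenzyl gives a 10-fold lower number from compound 2 to compound 3 (1.00 log units; beyond the scatter), a separation of this exchange that the earlier pair, in which the sulfur group and its substituent changed together, could not provide. Taken as a single exchange, (4-methylphenyl)sulfonyl in place of (4-methylbenzyl)sulfanyl gives a 25-fold lower number from compound 1 to compound 3 (1.40 log units; beyond the scatter), which makes compound 3 the strongest inhibitor of growth of the three. No supporting measurement accounts for either step.

The exchange from 2-chlorobenzyl to 4-methylphenyl alters the benzyl-to-phenyl link and the ring substituent together, so the compounds shown do not assign the step to either change alone. Also open, from the compounds shown here alone, is how a plain phenyl, or a longer chain ending in an amine, on the sulfonyl sulfur would compare with compound 3, and whether the number of compound 3 would hold with a sulfanyl in place of its sulfonyl.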